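The source may hold more compounds than are shown below. What is called first, only, known or untested is meant among the compounds shown, and "the series" means these compounds.

In a functional assay on MDA-MB-231 cells (Homo sapiens) for inhibition, read by MTT assay, with a stated time of 72 h (on this read-out higher numbers stand for weaker inhibition and lower numbers for stronger inhibition), compound 1 `CNC(=O)CCCCCCCn1nc(-c2cnc3[nH]ccc3c2)c2c(N)ncnc21` gives 15800 nM. Compound 2 `Nc1nc2cc(-c3nn(CCCCC(=O)NO)c4ncnc(N)c34)ccc2o1` gives 21200 nM, and compound 3 `Nc1nc2cc(-c3nn(CCCCCC(=O)NO)c4ncnc(N)c34)ccc2o1` gives 19000 nM. All three numbers lie within the usual scatter of one another, so compound 1 stands level with the other two.

Compound 4 `CNC(=O)CCCCCCCn1nc(-c2ccc3oc(N)nc3c2)c2c(N)ncnc21` keeps the shared core and the chain of compound 1 and changes one group, on an aromatic carbon of a five-membered aromatic ring with 2 nitrogen: a group of 10 heavy atoms (7 carbon, 2 nitrogen, 1 oxygen; one five-membered aromatic ring with 2 hetero atoms, one six-membered aromatic ring of carbon only) in place of a group of 9 heavy atoms (7 carbon, 2 nitrogen; one five-membered aromatic ring with 1 hetero atom, one six-membered aromatic ring with 1 hetero atom), on an aromatic carbon. The group that enters, 2-amino-1,3-benzoxazol-5-yl, is already carried by compound 2 and compound 3, although their chains end differently.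

Going by the values given here, no measured step isolates this swap. Among the compounds with values here, the only step available, a 1.1-fold lower number from compound 2 to compound 3 (0.05 log units; within the scatter), alters the chain rather than this group, and it shows that one chain change left the number within the scatter. Compound 1 and compound 3 differ in more than one place, and their values are also within the scatter of each other. In this assay, then, no shift beyond the scatter is expected, though this rests on only a few compounds.

The expected change is a 1.1-fold higher number from compound 1 to compound 4 (0.06 log units; within the scatter), which would be too small to separate from the scatter.

For compound 4 the estimated value is 18000 nM, with an expected range from 9000 nM to 36000 nM.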

Compound 4, half-maximal inhibitory concentration: 2900 nM
Compound 4: middle estimate off by 6.2-fold (0.79 log units), on the high side; the measured number lies below the stated range.
By their numbers in this assay, from the lowest: compound 4; then compounds 1, 3 and 2 (each within the scatter of the next).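

In this assay, going by these compounds alone, putting 2-amino-1,3-benzoxazol-5-yl on this aromatic carbon of the shared core gives a 5.4-fold lower number from compound 1 to compound 4 (0.74 log units; beyond the scatter), the first step in this set to lie beyond the scatter, so with this chain the group at this position does change the number. The group is not enough on its own: with it held fixed, 2-(methylcarbamoyl)ethyl in place of hydroxycarbamoyl gives a 6.6-fold lower number from compound 3 to compound 4 (0.82 log units; beyond the scatter), and 3-(methylcarbamoyl)propyl in place of hydroxycarbamoyl gives a 7.3-fold lower number from compound 2 to compound 4 (0.86 log units; beyond the scatter), so among these compounds the lower number appears only when this group is paired with the chain ending in the methyl amide. No measurement here accounts for why either change has this effect.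

As far as these compounds go, what remains open is which part of the entering group matters, since these compounds do not show whether an unsubstituted 1,3-benzoxazol-5-yl, without the amine, would keep the lower number. They also leave open how the number would respond if the methyl amide chain of compound 4 were made shorter or longer, or if it ended in a carboxylic acid.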